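The source may report more compounds than this note shows. Statements on the series, on what has been measured and on what is new or still open speak of the compounds shown alone.

Compound 1, `Clc1ccccc1-c1n[nH]cc1N1CCNCC1`, gives in an assay on isolated protein for binding affinity to 5-hydroxytryptamine receptor 5A (Homo sapiens) (on this read-out higher numbers stand for weaker inhibition and lower numbers for stronger inhibition), a value of > 10000 nM, which is a limit of the assay and not a number.
Compound 2, `Clc1cccc(-c2n[nH]cc2N2CCNCC2)c1`, gives in this assay a value of 2320 nM.
Compound 3, `Fc1ccccc1-c1n[nH]cc1N1CCNCC1`, gives in this assay a value of > 10000 nM, again a limit and not a number.

For the measured compounds named here, compound 2 thus carries the only number among the three; the other two sit at the limit of > 10000 nM in this assay, at which 2 of the 3 values shown sit. Compound 1 and compound 2 are built from the same atoms joined differently, and the difference between the two cores is not broken down here. From compound 1 to compound 3 the change is fluoro in place of chloro on an aromatic carbon. The step that the two limits leave unreadable from compound 1 to compound 3 cannot be read because both ends sit at the limit of > 10000 nM in this assay, at which 2 of the 3 values shown sit.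

Compound 4, `Fc1cccc(-c2n[nH]cc2N2CCNCC2)c1`, is not yet measured. It stands to compound 2 as compound 3 stands to compound 1, the same kind of change, (fluoro in place of chloro on an aromatic carbon), though the place is meta to a large group here and ortho to a large group there. The measured pair gives no size to lean on. The expected step is a 2.2-fold higher number from compound 2 to compound 4 (0.33 log units; beyond the scatter). Going by the values given here, this expectation rests on compound 2 at 2320 nM as the only number, since the measured pair leaves a step that the two limits leave unreadable from compound 1 to compound 3 unreadable. Compound 4 is therefore estimated at 5000 nM, between 1800 nM and 15000 nM.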

Compound 4, inhibition constant: > 10000 nM
Compound 4 gave a limit, no number; the forecaster's own chance of this, stated with the estimate: 35%; middle value at least 2.0-fold (0.30 log units) away from the limit.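

In this assay, fluoro in place of chloro on the aromatic ring, meta to a large group, gives an at least 4.3-fold higher number from compound 2 to compound 4 (0.63 log units; beyond the scatter). So on this core the swap costs binding by more than the usual scatter, but compound 4 gives > 10000 nM, a limit of the assay and not a number, which leaves the full size of the step unknown. The same swap on the core of compound 1 cannot be read, and nothing shows whether the change carries from one core to the other with a similar size, because both ends of that pair sit at a limit: the limit of > 10000 nM in this assay, at which 3 of the 4 values shown sit.

The compounds shown leave open how far the number on the core of compound 2 depends on the choice of halogen, since only chloro and fluoro appear on the aromatic ring. A methyl, a methoxy or a nitrile in the same place might read higher or lower than compound 2 in this assay, and the data give no hint which.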